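The compounds below may be only part of what the source reports. "The series", "measured", "known", "first", "only" and "open" are said of these compounds alone.

Compound 1 `C#CCNC1CCc2c(SCCc3cccc(Cl)c3)cccc21` carries a 3-chlorophenyl on a saturated chain carbon, two bonds along the chain from a sulfur. In an ADME assay on isolated protein for inhibition of Amine oxidase [flavin-containing] B (Homo sapiens) (on this read-out lower numbers stand for stronger inhibition and higher numbers for weaker inhibition), compound 1 gives "not determined" (no result reported), so there is no single number on which it can be placed. Compound 4 `C#CCNC1CCc2c(SCCc3ccc(Cl)cc3)cccc21` differs from it in one place: 4-chlorophenyl in place of 3-chlorophenyl on a saturated chain carbon, two bonds along the chain from a sulfur.

Within the data shown here, the only measured step is between compound 2 `C#CCNC1CCc2c(SCc3cccc(F)c3)cccc21` and compound 3 `C#CCNC1CCc2c(SCc3ccc(C)cc3)cccc21`, where the group sits on a shorter chain. In this assay compound 2 gives 11600 nM, compound 3 gives 320 nM, and a 36-fold lower number from compound 2 to compound 3 (1.56 log units; beyond the scatter). Among the measured compounds shown here, that step exchanges 3-fluorophenyl for 4-methylphenyl, a different pair of groups on a chain of different length, so it shows only that the aryl group can shift this read-out a great deal, not in which direction a chlorine move would act. For the measured compounds named here, with no number for compound 1, no step can be computed for compound 4, and the direction stays open.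

Compound 4 is therefore expected to fall in this assay near 1500 nM, within a wide range from 150 nM to 15000 nM.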

Compound 4, half-maximal inhibitory concentration: 920 nM
Estimate against measurement, compound 4: 1.6-fold (0.21 log units) above; low and high end bracket the measured number.
By their numbers in this assay, from the lowest: compound 3; then compound 4; then compound 2.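

In this assay compound 1 gives "not determined" (no result reported) and compound 4 gives 920 nM, so no step can be read between them. As far as these compounds go, whether 4-chlorophenyl or 3-chlorophenyl gives the lower number stays open, and no evidence at hand bears on this result.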